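The source may report more compounds than this note shows. Statements on the series, on what has been measured and on what is new or still open speak of the compounds shown alone.

Working notes on the series. Three compounds share one core and carry the same amide tail. Compound 1 `Cn1cc(-c2cc(C(C)(C)O)ccc2OC2CC2)c2cc(C(=O)NCc3ccc(C(=O)Nc4ccccc4N)cc3)[nH]c2c1=O` gives 40 nM in a functional assay on MV4-11 cells (Homo sapiens) for antiproliferative activity, read by CCK-8 assay, with a stated time of 72 h; on this read-out higher numbers stand for weaker inhibition and lower numbers for stronger inhibition. Compound 2 `Cn1cc(-c2cccc(C(C)(C)O)c2)c2cc(C(=O)NCc3ccc(C(=O)Nc4ccccc4N)cc3)[nH]c2c1=O` gives 2200 nM in this assay, the highest number of the three: the step of a 55-fold higher number from compound 1 to compound 2 (1.74 log units; beyond the scatter) and the step of a 9.2-fold lower number from compound 2 to compound 3 (0.96 log units; beyond the scatter) both lie beyond the scatter, so compound 2 stands furthest from compound 1 and next nearest to compound 3. Compound 3 `Cc1cc(F)cc(C)c1Oc1ccc(C(C)(C)O)cc1-c1cn(C)c(=O)c2[nH]c(C(=O)NCc3ccc(C(=O)Nc4ccccc4N)cc3)cc12` gives 240 nM in this assay; the step of a 6.0-fold higher number from compound 1 to compound 3 (0.78 log units; beyond the scatter) is the smaller of the two that start from compound 1.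

Compound 4 `Cn1cc(-c2cccc(F)c2)c2cc(C(=O)NCc3ccc(C(=O)Nc4ccccc4N)cc3)[nH]c2c1=O` is not yet measured. It differs from compound 2 in one place: fluoro in place of 1-hydroxy-1-methylethyl on an aromatic carbon. Going by the values given here, none of the measured steps touches this group; each of them changes what sits on the oxygen of the neighbouring ring, or removes that oxygen altogether, and the 1-hydroxy-1-methylethyl group is kept throughout. The expectation for compound 4 therefore rests on compound 2 alone, with 2200 nM as the anchor, and no step beyond the scatter is expected in this assay; the estimate is a 1.4-fold higher number from compound 2 to compound 4 (0.13 log units; within the scatter). Compound 4 is expected at 3000 nM, within 1000 nM to 10000 nM.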

Compound 4, half-maximal inhibitory concentration: 210 nM
The estimate for compound 4 lay 14-fold (1.15 log units) above the measured number, outside the stated range (below it).
By their numbers in this assay, from the lowest: compound 1; then compounds 4 and 3 (each within the scatter of the next); then compound 2.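

In this assay, going by these compounds alone, replacing 1-hydroxy-1-methylethyl with fluoro gives a 10-fold lower number from compound 2 to compound 4 (1.02 log units; beyond the scatter), the first evidence that this aromatic carbon, meta to a large group, affects the read-out, since the earlier compounds all keep 1-hydroxy-1-methylethyl there. The number for compound 2 is not set only by the missing cyclopropyloxy or 4-fluoro-2,6-dimethylphenoxy group. A single change at this carbon also moves it beyond the scatter. Nothing available explains this step.

The compounds shown leave open whether the step reflects the loss of 1-hydroxy-1-methylethyl or the arrival of fluoro, and how hydrogen, chloro, methyl, an amine or a carboxylic acid would read on this carbon. Also open, from the compounds shown here alone, is whether fluoro would give a similar step alongside the cyclopropyloxy group of compound 1.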